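Swapping the methoxy ester ring for a bromophenyl

The compounds below may be only part of what the source reports. "The series", "measured", "known", "first", "only" and "open" are said of these compounds alone.

Measured so far:
compound 1 `COc1cc(C(C)=O)ccc1OCCCN1CCC(C(c2ccc(F)cc2)c2ccc(F)c(F)c2)CC1` — 1.26 nM
compound 2 `COc1cc(C(C)=O)ccc1OCCCN1CCC(C(c2ccc(C)cc2)c2ccc(C)cc2)CC1` — 15.9 nM
compound 3 `COC(=O)c1ccc(OCCCN2CCC(C(c3ccc(F)cc3)c3ccc(F)cc3)CC2)c(OC)c1` — 1.26 nM

In a functional assay (aorta) with Oryctolagus cuniculus as the target (a higher number here means weaker binding, a lower number tighter binding), compound 3 gives 1.26 nM, level with compound 1 within the scatter; together they hold the lowest numbers of the three, while compound 2 lies beyond the scatter above them.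

Compound 4 `Fc1ccc(C(c2ccc(F)cc2)C2CCN(CCCOc3ccc(Br)cc3)CC2)cc1` is not yet measured. It differs from compound 3 in one place: 4-bromophenyl in place of 2-methoxy-4-(methoxycarbonyl)phenyl on an oxygen on a saturated carbon. Among the compounds with values here, no measured pair shows a change of this kind, so there is no step to lean on.

A modest weakening is expected, a step from compound 3 to compound 4 of a 2.5-fold higher number from compound 3 to compound 4 (0.40 log units; beyond the scatter). Compound 4 is estimated at 3.2 nM, expected to fall between 1 nM and 10 nM.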

Compound 4, dissociation constant: 1.59 nM
Compound 4: the middle estimate sits 2.0-fold (0.30 log units) above what was measured, and the stated range covers the measured number.
By their numbers in this assay, from the lowest: compounds 1, 3 and 4 (each within the scatter of the next); then compound 2.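

In this assay, the change on this oxygen gives a 1.3-fold higher number from compound 3 to compound 4 (0.10 log units; within the scatter), within the scatter. The 2-methoxy-4-(methoxycarbonyl)phenyl group, with 12 heavy atoms and 3 hydrogen-bond acceptors, can therefore give way to 4-bromophenyl, with 7 heavy atoms and no hydrogen-bond acceptors, without a change beyond the scatter. Nothing available explains why the two groups give such similar numbers. On these data alone, it remains open whether this tolerance extends to a phenyl ring carrying an amine or a carboxylic acid in place of the bromine.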